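Swapping a Furan for a Pyridine on a Shared Core

This account rests on a few compounds, and the source may have more. Where it says the series, first, only, none or still open, it means among the compounds named here.

Compound 1 `Oc1ccc(-c2cc(-c3ccco3)nc(-c3ccccc3Cl)c2)cc1` was tested in an assay on isolated protein for inhibition of DNA topoisomerase 1 (Homo sapiens), with a stated time of 30 min, tested at 100 uM (on this read-out higher numbers stand for a stronger effect at the one concentration tested and lower numbers for a weaker effect), where compound 1 reaches 3.9%. A second compound, compound 2 `Oc1cccc(-c2cc(-c3ccc(Cl)cc3)nc(-c3cccnc3)c2)c1`, was measured alongside it and in this assay compound 2 gives 2.8%. Of the two numbers, that of compound 1 is the higher, but compound 2 lies within the usual scatter of it, so the two cannot be told apart; both sit close to no effect at the single concentration tested.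

Compound 3 `Oc1ccc(-c2cc(-c3cccnc3)nc(-c3ccccc3Cl)c2)cc1` has not yet been measured. Compared with compound 1 it carries one change: pyridin-3-yl in place of furan-2-yl on an aromatic carbon. No comparable change between measured compounds is available to guide the expectation, and both measured values are low. Compound 3 is therefore expected to give about 4%, with a range from -6% to 15%. This means an expected step of a number 0.1 percentage points higher from compound 1 to compound 3 (within the scatter), none beyond the scatter.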

Compound 3, a percentage reported as inhibition, at one concentration (the size of the read-out at that concentration, not a potency): 0.9%
Compound 3: middle estimate off by 3.1 percentage points, on the high side; the range from low to high includes it.
By their numbers in this assay, from the lowest: compounds 3, 2 and 1 (each within the scatter of the next).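

In this assay, pyridin-3-yl in place of furan-2-yl gives a number 3 percentage points lower from compound 1 to compound 3 (within the scatter). Within the data shown here, this is the first direct comparison at this position, on an aromatic carbon next to the ring nitrogen, and it shows that the five-membered and the six-membered aromatic ring cannot be told apart here, with both compounds staying close to no effect. No measurement shown offers an explanation for this result.

Going by these compounds, with compounds this close to no effect, it remains open whether this position can influence the read-out at all, or whether the shared core itself limits the effect. Also open, on these data alone, is whether a group of another kind at this position, such as an aminomethyl group or a carboxylic acid, would move the number clear of the scatter.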